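Aryl amide exchange on compound 3: working notes

A few compounds are considered here, and "the series" means these few. Any claim that something is new, unique, unknown or untested is made for them only; others in the source may bear on it.

- Compound 1 `O=C1Nc2ccc(F)cc2/C1=C\C(=O)c1ccc(O)cc1F`: 1070 nM
- Compound 2 `O=C1Nc2ccc(F)cc2/C1=C\C(=O)c1ccc(C2CCCCC2)cc1`: 2520 nM
- Compound 3 `COc1ccc(C(=O)Nc2ccc3c(c2)/C(=C/Nc2cccc(N4CCN(C)CC4)c2)C(=O)N3)cc1`: 2010 nM

All three values come from a functional assay on HCT-116 cells (Homo sapiens) for inhibition, read by sulforhodamine B assay, with a stated time of 3 days; on this read-out lower numbers stand for stronger inhibition and higher numbers for weaker inhibition. Compound 3, at 2010 nM, lies within the scatter of both compound 1 and compound 2, so its place among the three numbers carries little weight on its own.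

The next compound to be measured is compound 4 `CN1CCN(c2cccc(N/C=C3\C(=O)Nc4ccc(NC(=O)c5cccc(F)c5)cc43)c2)CC1`. It keeps the shared core of compound 3 and changes one group: 3-fluorophenyl in place of 4-methoxyphenyl on a carbonyl carbon. In words, 3-fluorophenyl takes the place of 4-methoxyphenyl on a carbonyl carbon, whose other neighbour is an amide-type nitrogen.

Among the compounds with values here, neither compound 1 nor compound 2 differs from compound 3 in one place only, and no measured pair isolates this exchange. The data therefore give no direct measure of its effect. With nothing to suggest a large shift in either direction, no step beyond the scatter is expected in this assay, and the estimate stays anchored on compound 3 at 2010 nM. The expected change is a 1.1-fold lower number from compound 3 to compound 4 (0.05 log units; within the scatter). The estimated value for compound 4 is 1800 nM, with an expected range of 700 nM to 4500 nM.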

Compound 4, half-maximal inhibitory concentration: 2740 nM
For compound 4 the middle estimate is 1.5-fold (0.18 log units) below the measured one, within the range that was stated.
By their numbers in this assay, from the lowest: compounds 1, 3, 2 and 4 (each within the scatter of the next, the first and the last beyond it).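

In this assay, within the data shown here, replacing 4-methoxyphenyl with 3-fluorophenyl on the carbonyl carbon whose other neighbour is an amide-type nitrogen gives a 1.4-fold higher number from compound 3 to compound 4 (0.13 log units; within the scatter) and provides the first one-place comparison. At this level of activity, the two aryl amides cannot be told apart: the exchange of an 8-heavy-atom group carrying a hydrogen-bond acceptor for a 7-heavy-atom group carrying none produces no step beyond the scatter, although this single pair cannot show how far that holds for other groups at the position. The measurements shown offer no independent data that would account for this result.

The exchange alters both the substituent and its place on the phenyl ring, so this one step cannot separate the contribution of either change, and a small difference from each could be hidden within the scatter. Also open, as far as these compounds go, is the response of this assay to a carboxylic acid or a dimethylamino group on the phenyl ring, or to a longer alkyl chain in place of the ring on the carbonyl carbon.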